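The source may hold more compounds than are shown below. What is called first, only, known or untested is meant among the compounds shown, and "the series" means these compounds.

In a functional assay on PC-3 cells (Homo sapiens) for inhibition, read by MTT assay, with a stated time of 48 h (a higher number here means a weaker inhibitor, a lower number a stronger inhibitor), compound 2 `COc1cc(-c2nnc(S)n2-c2ccc(N(C)C)cc2)cc(OC)c1OC` gives > 60000 nM, which is a limit of the assay and not a number. Compound 1 `COc1ccc(-n2c(SC)nnc2-c2cc(OC)c(OC)c(OC)c2)cc1` gives > 60000 nM, which is also a limit. Among the measured compounds shown here, the record so far is therefore (the limit of > 60000 nM in this assay, at which 2 of the 2 values shown sit), and no measured step between compounds is available as a guide. Compound 3 `COc1cc(-c2nnc(SC)n2-c2ccc(N(C)C)cc2)cc(OC)c1OC` differs from compound 2 in one place, with methyl in place of hydrogen on a sulfur, which turns sulfanyl to methylsulfanyl (methyl in place of hydrogen on a sulfur). Compound 1 already carries a methylsulfanyl group and still gives > 60000 nM, so only a modest move towards stronger inhibition in this assay is expected, or none beyond the scatter. The expected change is an at least 2.0-fold lower number from compound 2 to compound 3 (0.30 log units; that floor lies within the scatter). For compound 3 the estimated value is 30000 nM, within an expected range of 6000 nM to 60000 nM.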

Compound 3, half-maximal inhibitory concentration: > 60000 nM
Compound 3: no number, only a limit (the forecaster's own chance of this, stated with the estimate: 50%); at least 2.0-fold (0.30 log units) between middle value and limit.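

Compound 1, compound 2 and compound 3 all give only a limit in this assay, so the steps from compound 2 to compound 3 and from compound 1 to compound 3 cannot be read: the limit of > 60000 nM in this assay, at which 3 of the 3 values shown sit. The compounds shown leave open whether either change, methyl in place of hydrogen on a sulfur or dimethylamino in place of methoxy, alters inhibition at all.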